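Three Benzamides at the Limit, and a Trifluoromethyl Analogue

The compounds below may be only part of what the source reports. "The series", "measured", "known", "first", "only" and "open" are said of these compounds alone.

Compound 1 `Cc1ccc(S(=O)(=O)N[C@@H](CC(=O)NC(C)(C)C)C(=O)NCCNC(=O)c2cccc(O)c2)cc1` gives > 11000 nM in an ADME assay on HepG2 cells (Homo sapiens) for cytotoxicity (a lower number here means that less compound is needed, a higher number that more compound is needed for the effect), a limit of the assay.
Compound 2 `Cc1ccc(S(=O)(=O)N[C@@H](CC(=O)NC(C)(C)C)C(=O)NCCNC(=O)c2cccc(C(C)C)c2)cc1` gives > 11000 nM, also a limit.
Compound 3 `Cc1ccc(S(=O)(=O)N[C@@H](CC(=O)NC(C)(C)C)C(=O)NCCNC(=O)c2ccc(F)c(F)c2)cc1` gives > 11000 nM, again a limit.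

Compound 1 therefore stands only at a limit, as do the other two, and the limit of > 11000 nM in this assay, at which 3 of the 3 values shown sit, sums up the whole picture. The measured steps a step that the two limits leave unreadable from compound 1 to compound 2 and a step that the two limits leave unreadable from compound 1 to compound 3 are both unreadable, so no size in this assay can be taken from them. Compound 4 `Cc1ccc(S(=O)(=O)N[C@@H](CC(=O)NC(C)(C)C)C(=O)NCCNC(=O)c2cccc(C(F)(F)F)c2)cc1` differs from compound 1 by trifluoromethyl in place of hydroxy on an aromatic carbon. Among the compounds with values here, because the limit of > 11000 nM in this assay, at which 3 of the 3 values shown sit, holds for every value so far, the account expects no step beyond the scatter, that is a step that the limit leaves unreadable from compound 1 to compound 4. Compound 4 is expected at 15000 nM, between 8000 nM and 40000 nM.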

Compound 4, half-maximal effective concentration: > 11000 nM
Compound 4 gave a limit, no number; the forecaster's own chance of this, stated with the estimate: 85%; the middle value lies beyond the limit too.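

Compound 4 stands at a limit, as do compound 1, compound 2 and compound 3, so no step among these compounds can be read: the limit of > 11000 nM in this assay, at which 4 of the 4 values shown sit.

The compounds shown leave open what concentration of any of them would reach the half-way effect in this assay, and how far they differ there.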